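A few compounds are considered here, and "the series" means these few. Any claim that something is new, unique, unknown or untested is made for them only; others in the source may bear on it.

The measured compounds, each tested in a functional assay on PC-9 cells (Homo sapiens) for inhibition, read by MTT assay, with a stated time of 72 h; a lower number here means a stronger inhibitor, a higher number a weaker inhibitor:

Compound 1, `Cc1cc(Nc2cc(-c3ccccc3)[nH]n2)n2nc(SCCCc3ccccc3)nc2n1`, gives 5030 nM.
Compound 2, `Cc1cc(Nc2cc(-c3ccccc3)[nH]n2)n2ncnc2n1`, gives only a limit of the assay, > 50000 nM, not a number.
Compound 3, `Cc1cc(Nc2cc(-c3ccccc3)[nH]n2)n2nc(SCc3csc4ccccc34)nc2n1`, gives 4420 nM.

Compound 3 holds the lowest of the two numbers, but its nearest neighbour is compound 1, and the step of a 1.1-fold lower number from compound 1 to compound 3 (0.06 log units; within the scatter) sits within the scatter, so the two cannot be told apart. That step swaps the ring on the saturated chain carbon bound to a sulfur and changed little. The larger movement is an at least 11-fold lower number from compound 2 to compound 3 (1.05 log units; beyond the scatter), where the ((1-benzothiophen-3-yl)methyl)sulfanyl group is added to the shared core; the reverse, removing the (3-phenylpropyl)sulfanyl group, appears as an at least 9.9-fold higher number from compound 1 to compound 2 (0.99 log units; beyond the scatter).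

Compound 4, `Cc1cc(Nc2cc(-c3ccccc3)[nH]n2)n2nc(SCc3ccc(Cl)cc3)nc2n1`, keeps a sulfanyl group and differs from compound 3 only there: 4-chlorophenyl in place of 1-benzothiophen-3-yl on a saturated chain carbon bound to a sulfur. The step that bears on it is the earlier ring swap at the same place, which stayed within the scatter, so the move to compound 4 is expected to be a 1.0-fold higher number from compound 3 to compound 4 (0.01 log units; within the scatter) in this assay, nothing beyond the scatter. Compound 4 is therefore estimated at 4500 nM, with a range from 2000 nM to 10000 nM.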

Compound 4, half-maximal inhibitory concentration: 6710 nM
Estimate against measurement, compound 4: 1.5-fold (0.17 log units) below; the measured number falls inside the stated range.
By their numbers in this assay, from the lowest: compounds 3, 1 and 4 (each within the scatter of the next). At a limit, above all of these: compound 2.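

In this assay, the single six-membered ring of 4-chlorophenyl does as well as the two rings of 1-benzothiophen-3-yl, a 1.5-fold higher number from compound 3 to compound 4 (0.18 log units; within the scatter), and it also cannot be told apart from phenethyl, a 1.3-fold higher number from compound 1 to compound 4 (0.13 log units; within the scatter), so three quite different groups on this saturated chain carbon bound to a sulfur now give no order among themselves. The (4-chlorobenzyl)sulfanyl group also stands clear of the bare core, an at least 7.4-fold lower number from compound 2 to compound 4 (0.87 log units; beyond the scatter), which makes all three sulfanyl compounds shown better than the compound with hydrogen at that place. Compound 2 gives a limit and not a number, so the true size of these steps stays unknown: the limit of > 50000 nM in this assay, at which 1 of the 4 values shown sits.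

As far as these compounds go, it remains open whether a group of another kind at the end of the sulfanyl chain, such as an amine or a carboxylic acid, would move the number beyond the scatter. A plain ethyl chain on the sulfur would show whether a ring is needed there at all.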